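A Pyrazole in Place of a Fluoropyridine on Compound 1

The source may hold more compounds than are shown below. What is called first, only, known or untested is meant among the compounds shown, and "the series" means these compounds.

Measured so far:
compound 1 `COc1ccc(CNC(=O)c2cc(-c3cncc(C)c3)ncc2-c2cncc(F)c2)nc1OC`: 10000 nM
compound 2 `COc1ccc(CNC(=O)c2sc(-c3cncc(C)c3)nc2-c2cccc(F)c2)nc1OC`, reported only as a limit: > 10000 nM

In an assay on CHO cells for antagonist activity at Orexin/Hypocretin receptor type 1 variant I408V (Homo sapiens), read by FLIPR, with a stated time of 5 min (a higher number here means a weaker inhibitor, a lower number a stronger inhibitor), compound 1 gives 10000 nM. That is the only number shown; the other value is the limit of > 10000 nM in this assay, at which 1 of the 2 values shown sits. In this assay compound 2 gives > 10000 nM, which is a limit of the assay and not a number. Going by the values given here, compound 1 and compound 2 also differ in their core, so their two values say only that compound 1 has a measured number and compound 2 does not.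

Compound 3 `COc1ccc(CNC(=O)c2cc(-c3cncc(C)c3)ncc2-c2cnn(C)c2)nc1OC` changes compound 1 in one place: 1-methyl-1H-pyrazol-4-yl in place of 5-fluoropyridin-3-yl on an aromatic carbon. The 1-methyl-1H-pyrazol-4-yl enters on an aromatic carbon of a six-membered aromatic ring with 1 nitrogen, ortho to a large group, two atoms from the ring nitrogen and para to the 5-methylpyridin-3-yl group.

Among the compounds with values here, no measured step tells what such an exchange does here. The account therefore expects no change beyond the scatter, with the value of compound 3 estimated at about the same level as compound 1, since compound 1 already sits at 10000 nM. Compound 3 is estimated at 10000 nM, between 3000 nM and 30000 nM. The expected step from compound 1 to compound 3 is no change at the digits printed from compound 1 to compound 3 (within the scatter).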

Compound 3, half-maximal inhibitory concentration: 10000 nM
The estimate for compound 3 equals the measured number at the digits printed, and the stated range covers the measured number.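

In this assay, going by these compounds alone, the exchange of 5-fluoropyridin-3-yl for 1-methyl-1H-pyrazol-4-yl provides the only measured step at this position, on an aromatic carbon ortho to a large group and para to a 5-methylpyridin-3-yl group, and it reads: no change at the digits printed from compound 1 to compound 3 (within the scatter). At this place, then, a five-membered aromatic ring with 2 hetero atoms and a six-membered aromatic ring with 1 hetero atom leave the value as printed, so this position now has a measured exchange that the two earlier compounds could not supply. Compound 2 remains the one compound reported only as a limit, which is not a number: the limit of > 10000 nM in this assay, at which 1 of the 3 values shown sits.

The compounds shown leave open whether a group of another kind at this place, such as an amine, a carboxylic acid or a longer alkyl chain, would give a value different from that of compound 1. They also leave open whether the same exchange would read alike on a compound with a much lower number in this assay.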